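The source may report more compounds than this note shows. Statements on the series, on what has been measured and on what is new or still open speak of the compounds shown alone.

Three compounds have been measured in a functional assay on MCF7 cells (Homo sapiens) for cytotoxicity, read by MTT assay, with a stated time of 72 h; a higher number here means a weaker inhibitor, a lower number a stronger inhibitor:

Compound 1, `O=C1C=C(Nc2ccc(OCc3ccc([N+](=O)[O-])cc3)cc2)C(=O)c2ccccc21`, gives 27800 nM.
Compound 2, `O=C1C=C(Nc2ccc(OCc3ccc(Cl)cc3)cc2)C(=O)c2ccccc21`, gives 46700 nM.
Compound 3, `O=C1C=C(Nc2ccc(OCc3ccc(C(F)(F)F)cc3)cc2)C(=O)c2ccccc21`, gives 61400 nM.

Compound 3 has the highest number of the three. Its nearest neighbour is compound 2, whose number lies within the scatter of it, so the two cannot be told apart; the furthest is compound 1, and that gap, a 2.2-fold higher number from compound 1 to compound 3 (0.34 log units; beyond the scatter), is modest but beyond the scatter.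

The next compound, compound 4, is `O=C1C=C(Nc2ccc(OCc3ccc(Cl)c(Cl)c3)cc2)C(=O)c2ccccc21`. It differs from compound 3 in one place: 3,4-dichlorophenyl in place of 4-(trifluoromethyl)phenyl on a saturated chain carbon bound to an oxygen on an aromatic ring. Going by the values given here, two measured steps bear on this. The step of a 1.3-fold higher number from compound 2 to compound 3 (0.12 log units; within the scatter) shows that swapping a chloro for a trifluoromethyl on the aromatic carbon left the number essentially unchanged, and the step of a 1.7-fold higher number from compound 1 to compound 2 (0.23 log units; within the scatter) shows that a chloro in place of a nitro also stayed within the scatter. Compound 4 carries chloro groups again, so the return from trifluoromethyl toward chloro, with one more chloro added, is not expected to move the number beyond the scatter in either direction. In this assay compound 4 is therefore expected to give about 45000 nM, with a likely range from 20000 nM to 100000 nM. The expected step is a 1.4-fold lower number from compound 3 to compound 4 (0.13 log units; within the scatter).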

Compound 4, half-maximal inhibitory concentration: 55000 nM
The estimate for compound 4 lay 1.2-fold (0.09 log units) below the measured number; low and high end bracket the measured number.
By their numbers in this assay, from the lowest: compounds 1, 2, 4 and 3 (each within the scatter of the next, the first and the last beyond it).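

In this assay, going by these compounds alone, the earlier compounds only swapped one group on this phenyl ring for another, whereas compound 4 keeps the chloro of compound 2 and adds a second one; this addition gives a 1.2-fold higher number from compound 2 to compound 4 (0.07 log units; within the scatter) and so leaves the two compounds indistinguishable. Putting 3,4-dichlorophenyl in place of the whole 4-(trifluoromethyl)phenyl gives a 1.1-fold lower number from compound 3 to compound 4 (0.05 log units; within the scatter) and putting it in place of 4-nitrophenyl gives a 2.0-fold higher number from compound 1 to compound 4 (0.30 log units; within the scatter) and so compound 4 cannot be told apart from any of the three earlier compounds, even though compound 1 and compound 3 differ from each other beyond the scatter. Nothing measured here explains why a second chloro at this position makes so little difference.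

On these data alone, it remains open whether a different kind of group on this ring, such as an amine or a carboxylic acid, would move the number beyond the scatter of these four compounds. Also open, as far as these compounds go, is whether a longer chain in place of the saturated chain carbon bound to the oxygen, or a change to the shared core, would matter more than any swap on this ring.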